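Steryl-sulfatase inhibition: from compound 1 to compound 3

The compounds below may be only part of what the source reports. "The series", "measured", "known", "first", "only" and "open" are said of these compounds alone.

Compound 1 `CC(C)(C)OC(=O)N1CCC(C(=O)NS(=O)(=O)c2cccc(Cl)c2)CC1` gives 71000 nM in an assay on isolated protein for inhibition of Steryl-sulfatase (Homo sapiens) (on this read-out higher numbers stand for weaker inhibition and lower numbers for stronger inhibition), the highest of the two numbers in hand; compound 2 `COc1ccc(OC)c(S(=O)(=O)NC(=O)C2CCN(C(=O)OC(C)(C)C)CC2)c1` gives 1900 nM, a gap beyond the scatter. Among the compounds with values here, compound 3 `CC(C)(C)OC(=O)N1CCC(C(=O)NS(=O)(=O)Cc2cc(Cl)cc(Cl)c2)CC1` differs from compound 1 by 3,5-dichlorobenzyl in place of 3-chlorophenyl on a sulfonyl sulfur, and no measured pair shows this kind of change. The step from compound 1 to compound 3 is therefore expected to be small, a 1.4-fold lower number from compound 1 to compound 3 (0.15 log units; within the scatter), with no direction beyond the scatter claimed. Compound 3 is estimated at 50000 nM in this assay, within a range from 10000 nM to 200000 nM.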

Compound 3, half-maximal inhibitory concentration: 10200 nM
Compound 3: middle estimate off by 4.9-fold (0.69 log units), on the high side; measured number inside the range.
By their numbers in this assay, from the lowest: compound 2; then compound 3; then compound 1.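

In this assay, 3,5-dichlorobenzyl in place of 3-chlorophenyl on a sulfonyl sulfur gives a 7.0-fold lower number from compound 1 to compound 3 (0.84 log units; beyond the scatter), so the group at this position can shift the read-out beyond the scatter. The change adds one carbon and one chlorine together, and this single pair cannot separate the two additions. Nothing available here accounts for the step. As far as these compounds go, it remains open whether unsubstituted benzyl or 3-chlorobenzyl would carry the same shift. From the compounds shown here alone, how a longer chain such as 2-phenylethyl, or a carboxylic acid on the aromatic ring, would read is also open.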